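Cytotoxicity of Three Esters and a Fourth to Come

The source may report more compounds than this note shows. Statements on the series, on what has been measured and on what is new or still open speak of the compounds shown alone.

Compound 1 `CC12CCC(C(=O)OCCc3c(-c4ccccc4Cl)c4cc(Cl)ccc4[nH]c3=O)(OC1=O)C2(C)C` gives in an ADME assay on HepG2 2.2.15 cells (Homo sapiens) for cytotoxicity; a lower number here means that less compound is tolerated, a higher number that more compound is tolerated > 1800000 nM, which is a limit of the assay and not a number. Compound 2 `O=C(OCCc1c(-c2ccccc2Cl)c2cc(Cl)ccc2[nH]c1=O)c1cccnc1` gives in this assay 170000 nM. Compound 3 `O=C(CCOc1ccccc1)OCCc1c(-c2ccccc2Cl)c2cc(Cl)ccc2[nH]c1=O` gives in this assay 46000 nM.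

Compound 3 has the lowest of the two numbers, with compound 2 the nearest, as a 3.7-fold lower number from compound 2 to compound 3 (0.57 log units; beyond the scatter) shows. Compound 4 `O=C(/C=C/c1cccnc1)OCCc1c(-c2ccccc2Cl)c2cc(Cl)ccc2[nH]c1=O` is not yet measured. It differs from compound 3 in one place: 2-(pyridin-3-yl)ethenyl in place of 2-phenoxyethyl on a carbonyl carbon.

For the measured compounds named here, only one measured step bears on this change. a 3.7-fold lower number from compound 2 to compound 3 (0.57 log units; beyond the scatter) was modest and ran from a pyridin-3-yl group toward the 2-phenoxyethyl group that now leaves. Compound 4 brings a pyridine ring back, though through a two-carbon linker with a double bond rather than directly on the carbonyl carbon, so a partial return toward compound 2 is expected: a modest step to a higher number in this assay is estimated for compound 4, a 2.0-fold higher number from compound 3 to compound 4 (0.29 log units; within the scatter). Compound 4 is therefore expected to give about 90000 nM, with a range of 30000 nM to 300000 nM.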

Compound 4, half-maximal cytotoxic concentration: 39000 nM
The estimate for compound 4 lay 2.3-fold (0.36 log units) above the measured number; low and high end bracket the measured number.
By their numbers in this assay, from the lowest: compounds 4 and 3 (each within the scatter of the next); then compound 2. At a limit, above all of these: compound 1.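

On this carbonyl carbon, compounds 3 and 4 cannot be told apart in this assay, a 1.2-fold lower number from compound 3 to compound 4 (0.07 log units; within the scatter), so bringing back a pyridine ring did not by itself bring back the number of compound 2. Compounds 2 and 4 both carry that ring yet lie beyond the scatter of each other, a 4.4-fold lower number from compound 2 to compound 4 (0.64 log units; beyond the scatter), so the ring alone does not set the number, and the ethenyl link goes with a real difference. Compound 1 gives a limit of the assay and not a number, so one step is only a bound, an at least 46-fold lower number from compound 1 to compound 4 (1.66 log units; beyond the scatter), and the limit itself reads: the limit of > 1800000 nM in this assay, at which 1 of the 4 values shown sits.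

The compounds shown do not separate the double bond from the ring nitrogen: a saturated ethyl link to the same pyridine ring, or a plain phenyl ring on the ethenyl, would do so. Going by these compounds, how an amine or a carboxylic acid on this chain would read also stays open.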